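This account rests on a few compounds, and the source may have more. Where it says the series, first, only, none or still open, it means among the compounds named here.

Compound 1, `Cc1nsc2[nH]cnc12`, is the simplest member of this small set. In a functional assay on HFF cells (Homo sapiens) for inhibition (on this read-out lower numbers stand for stronger inhibition and higher numbers for weaker inhibition), compound 1 gives 32000 nM. Compound 2, `CSc1nc2c(C)nsc2[nH]1`, differs from compound 1 in one place: methylsulfanyl in place of hydrogen on an aromatic carbon. In this assay compound 2 gives 26000 nM. The step of a 1.2-fold lower number from compound 1 to compound 2 (0.09 log units; within the scatter) is thus a small one, and the two values cannot be told apart. Compound 3, `Cc1nsc2ncn([C@H]3C[C@H](O)[C@@H](CO)O3)c12`, carries a much larger piece than compound 1; how its core differs from the core of compound 1 is not broken down here. In this assay compound 3 gives > 100000 nM, which is a limit of the assay and not a number. For the measured compounds named here, compound 3 is the one value that sits at the limit of > 100000 nM in this assay, at which 1 of the 3 values shown sits. Compound 4, `CSc1nc2snc(C)c2n1[C@H]1C[C@H](O)[C@@H](CO)O1`, has not yet been tested in this assay. It differs from compound 3 by the same kind of change that separates compound 2 from compound 1: methylsulfanyl in place of hydrogen on an aromatic carbon. The surroundings of the place are not identical, since in compound 4 the new group sits next to the ring atom that bears a group of 8 heavy atoms, which is not said of compound 2. Because the earlier step of a 1.2-fold lower number from compound 1 to compound 2 (0.09 log units; within the scatter) stayed within the scatter, the step that the limit leaves unreadable from compound 3 to compound 4 is expected to be small as well. Compound 4 is therefore expected to give about 120000 nM, most likely between 40000 nM and 400000 nM, and it may well return only a limit again.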

Compound 4, half-maximal inhibitory concentration: 32000 nM
Beside the measured number, compound 4's estimate is 3.8-fold (0.57 log units) above it; measured number outside the range, below it.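

In this assay, methylsulfanyl in place of hydrogen on an aromatic carbon gives an at least 3.1-fold lower number from compound 3 to compound 4 (0.49 log units; beyond the scatter), a step beyond the scatter on the core that carries the large group of 8 heavy atoms, whereas the same change on the core of compound 1 gave a step within the scatter. Compound 3 gives > 100000 nM, which is a limit of the assay and not a number. Set side by side, the two steps show that the change can be read on one core and not on the other, but they do not show that its size truly depends on the core, and two pairs of compounds make no rule for the series: the same change on two cores in this assay, a 1.2-fold lower number (0.09 log units; within the scatter) from compound 1 to compound 2 and an at least 3.1-fold lower number (0.49 log units; beyond the scatter) from compound 3 to compound 4; the limit leaves it open whether they differ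

What the compounds shown leave open is whether the readable step belongs to methylsulfanyl in particular, since no other group appears on this aromatic carbon, such as an amine, a carboxylic acid or a longer chain like ethylsulfanyl. Going by these compounds, it also remains open how the same change would behave on a core where the group of 8 heavy atoms is replaced by another one.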